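A few compounds are considered here, and "the series" means these few. Any claim that something is new, unique, unknown or untested is made for them only; others in the source may bear on it.

Measured so far:
- compound 1, `COc1ccc(C[C@@H](O)/C=C/C=C/C(=O)NCc2ccccc2)cc1OC`: 17100 nM
- compound 2, `COc1ccc(C[C@@H](O)/C=C/C=C/C(=O)NCc2cc(OC)c(OC)c(OC)c2)cc1OC`: 19200 nM

In a functional assay on A549 cells (Homo sapiens) for antiproliferative activity, read by sulforhodamine B assay, with a stated time of 48 h (on this read-out lower numbers stand for stronger inhibition and higher numbers for weaker inhibition), compound 1 gives 17100 nM, and compound 2 gives 19200 nM. These two numbers sit within the usual scatter of each other, so neither compound stands apart; both act only weakly on this cell line. Compound 3, `COc1ccc(C[C@@H](O)/C=C/C=C/C(=O)N2CCCCC2)cc1OC`, has not yet been measured. It differs from compound 1 in one place: piperidin-1-yl in place of benzylamino on a carbonyl carbon. Whether the amide hydrogen or the aromatic ring of the benzylamino group matters for this activity is not shown by compound 1 or compound 2, so the step is uncertain. The expectation is that compound 3 stays in the same weak range, with a step of a 1.2-fold higher number from compound 1 to compound 3 (0.09 log units; within the scatter) that is small and not beyond the scatter. Compound 3 is therefore estimated at 21000 nM, within a range from 8000 nM to 60000 nM.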

Compound 3, half-maximal inhibitory concentration: 16400 nM
The estimate for compound 3 lay 1.3-fold (0.11 log units) above the measured number, and the stated range covers the measured number.
By their numbers in this assay, from the lowest: compounds 3, 1 and 2 (each within the scatter of the next).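

In this assay, piperidin-1-yl in place of benzylamino on the carbonyl carbon gives a 1.0-fold lower number from compound 1 to compound 3 (0.02 log units; within the scatter) and so leaves the number within the scatter. The group that enters has no aromatic ring and no hydrogen-bond donor, so neither feature of benzylamino is needed to hold activity at this weak level, and this position accepts both an open benzylamino group and a closed piperidine ring without a measurable change. No measurement here explains why the two groups read alike.

Still open, from the compounds shown here alone, is whether morpholin-4-yl or dimethylamino on this carbonyl carbon, or a carboxylic acid in place of the whole amide, would move the number beyond the scatter. Also open, going by these compounds, is whether any change to the rest of the shared core would give stronger inhibition.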